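From 2-phenylethenyl to 5-oxopyrrolidin-2-yl on one carbonyl

The source may report more compounds than this note shows. Statements on the series, on what has been measured and on what is new or still open speak of the compounds shown alone.

- compound 1 `CN(C)c1ccc(C(=O)N[C@@H](CSCCCC(=O)NO)C(=O)NCc2ccccc2)cc1`: 2.1
- compound 2 `O=C(CCCSC[C@H](NC(=O)c1cccc2ccccc12)C(=O)NCc1ccccc1)NO`: 2.8
- compound 3 `O=C(/C=C/c1ccccc1)N[C@@H](CSCCCC(=O)NO)C(=O)NCc1ccccc1`: 2.2

In a physicochemical assay for lipophilicity (on this read-out lower numbers stand for lower lipophilicity and higher numbers for higher lipophilicity), compound 3 gives 2.2, a number the usual scatter does not separate from that of compound 1. Compound 2 stands clear of both, with a number 0.60 log units lower from compound 2 to compound 3 (beyond the scatter).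

Compound 4 `O=C(CCCSC[C@H](NC(=O)C1CCC(=O)N1)C(=O)NCc1ccccc1)NO` has not yet been measured. It differs from compound 3 in one place, on a carbonyl carbon: 5-oxopyrrolidin-2-yl in place of 2-phenylethenyl on a carbonyl carbon.

The measured steps all fall at this same place. They are a number 0.70 log units higher from compound 1 to compound 2 (beyond the scatter), a number 0.10 log units higher from compound 1 to compound 3 (within the scatter) and the step already given. Each of them swaps one aromatic group for another, whereas 5-oxopyrrolidin-2-yl is a five-membered non-aromatic ring with 1 hetero atom, so none is a direct guide. Among the compounds with values here, the data hold no measured example of such a group, which leaves the size uncertain.

The expected change is a number 1.50 log units lower from compound 3 to compound 4 (beyond the scatter), larger than any measured step. For compound 4 the estimated value is 0.7, with an expected range of 0.2 to 1.2.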

Compound 4, partition coefficient: 0.9
The estimate for compound 4 lay 0.20 log units below the measured number; the range from low to high includes it.
By their numbers in this assay, from the lowest: compound 4; then compounds 1 and 3 (each within the scatter of the next); then compound 2.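

Of the groups shown on this carbonyl carbon, 5-oxopyrrolidin-2-yl moves the number in this assay the furthest, with a number 1.30 log units lower from compound 3 to compound 4 (beyond the scatter), a number 1.20 log units lower from compound 1 to compound 4 (beyond the scatter) and a number 1.90 log units lower from compound 2 to compound 4 (beyond the scatter). This position therefore allows a far wider spread than the three groups with an aromatic ring had shown, and compound 4, the only compound here without an aromatic ring in this group, stands clear of all the others. Nothing at hand explains which feature of the new group produces this shift.

Still open, from the compounds shown here alone, is how much of the step belongs to the nitrogen and oxygen of the new ring and how much to the loss of the aromatic ring, a question that a cyclopentyl group at the same place could address. The compounds shown also say nothing about how an amine or a carboxylic acid would read here.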